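This account rests on a few compounds, and the source may have more. Where it says the series, first, only, none or still open, it means among the compounds named here.

Measured compounds:
compound 1, `CC(O)(COc1cccc(C(F)(F)F)c1)C(=O)Nc1ccc(S(F)(F)(F)(F)F)cc1`: 14600 nM
compound 2, `CC(O)(COc1ccc(C#N)cc1)C(=O)Nc1ccc(S(F)(F)(F)(F)F)cc1`: 26100 nM
compound 3, `CC(O)(COc1ccc(C#N)cc1C(F)(F)F)C(=O)Nc1ccc(S(F)(F)(F)(F)F)cc1`: 13800 nM

All three numbers come from a functional assay on CWR22R cells (Homo sapiens) for antiproliferative activity, read by propidium iodide staining, with a stated time of 96 h; on this read-out lower numbers stand for stronger inhibition and higher numbers for weaker inhibition. Compound 2 differs from compound 1 by 3-(trifluoromethyl)phenyl in place of 4-cyanophenyl on an oxygen on a saturated carbon; the step is a 1.8-fold higher number from compound 1 to compound 2 (0.25 log units; within the scatter). Compound 3 differs from compound 2 by trifluoromethyl in place of hydrogen on an aromatic carbon, and here a 1.9-fold lower number from compound 2 to compound 3 (0.28 log units; within the scatter).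

Compound 4, `CC(O)(COc1cc(C(F)(F)F)cc(C(F)(F)F)c1)C(=O)Nc1ccc(S(F)(F)(F)(F)F)cc1`, is not yet measured. It differs from compound 1 by trifluoromethyl in place of hydrogen on an aromatic carbon. This is the same kind of change as that from compound 2 to compound 3, but not the same: in compound 3 the entering group sits ortho to a large group and meta to a cyano group, whereas in compound 4 it sits meta to a large group and meta to a trifluoromethyl group. Because a 1.9-fold lower number from compound 2 to compound 3 (0.28 log units; within the scatter) stayed within the scatter, a step of similar size is expected in this assay, a 1.6-fold lower number from compound 1 to compound 4 (0.21 log units; within the scatter), resting on that single precedent only. For compound 4 the estimate is 9000 nM, with the range 4000 nM to 22000 nM.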

Compound 4, half-maximal inhibitory concentration: 7000 nM
Estimate against measurement, compound 4: 1.3-fold (0.11 log units) above, and the stated range covers the measured number.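

In this assay, trifluoromethyl in place of hydrogen on an aromatic carbon gives a 2.1-fold lower number from compound 1 to compound 4 (0.32 log units; beyond the scatter), a modest step. Set beside the earlier case, the change carries from one core to the other with no difference that can be told apart: the same change on two cores in this assay, a 1.9-fold lower number (0.28 log units; within the scatter) from compound 2 to compound 3 and a 2.1-fold lower number (0.32 log units; beyond the scatter) from compound 1 to compound 4, 1.1-fold (0.04 log units) apart, within the scatter of two such steps. This is agreement between two pairs only, both towards a lower number and neither going against the other, with one step printed within the scatter and the other just beyond it, so it supports carrying the change between the cores of compound 1 and compound 2 but gives no rule for the wider series and no reason for the effect.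

Still open, from the compounds shown here alone, is whether an amine, a methoxy group or a chlorine entering in place of the same hydrogen would give a step of similar size. Also open, going by these compounds, is whether the step survives when the pentafluorosulfanyl group of the shared core is exchanged for a nitrile or a nitro group.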